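Fluorophenyl sulfonyl analogue on the six-membered amine ring

This account rests on a few compounds, and the source may have more. Where it says the series, first, only, none or still open, it means among the compounds named here.

Compound 3 `O=S(=O)(c1cccc(Cl)c1)c1cn(C2CCCNC2)c2ncccc12` gives 1.3 nM in an assay on HeLa cells for displacement of a labelled ligand from 5-hydroxytryptamine receptor 6 (Homo sapiens) (a lower number here means a stronger inhibitor, a higher number a weaker inhibitor), the lowest of the three numbers: compound 1 `O=S(=O)(c1ccccc1F)c1cn(C2CCNC2)c2ncccc12` gives 2 nM, and compound 2 `O=S(=O)(c1ccccc1)c1cn(C2CCCNC2)c2ncccc12` gives 4.9 nM. Within the data shown here, the only one-point step, a 3.8-fold lower number from compound 2 to compound 3 (0.58 log units; beyond the scatter), lies beyond the scatter. Compound 4 `O=S(=O)(c1ccccc1F)c1cn(C2CCCNC2)c2ncccc12` differs from compound 3 by 2-fluorophenyl in place of 3-chlorophenyl on a sulfonyl sulfur. Among the measured compounds shown here, no measured step shows this exact exchange; compound 1 carries the same 2-fluorophenyl on a different amine ring, and its value and that of compound 3 sit within the scatter of each other. Compound 4 is therefore expected to give about 2.5 nM (range 1 nM to 6 nM) in this assay. The expected step of a 1.9-fold higher number from compound 3 to compound 4 (0.28 log units; within the scatter) would stay within the scatter.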

Compound 4, inhibition constant: 2 nM
Estimate against measurement, compound 4: 1.3-fold (0.10 log units) above, and the stated range covers the measured number.
By their numbers in this assay, from the lowest: compounds 3, 1 and 4 (each within the scatter of the next); then compound 2.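

In this assay, 2-fluorophenyl and 3-chlorophenyl on the sulfonyl sulfur are not separated on the piperidin-3-yl compounds (a 1.5-fold higher number from compound 3 to compound 4 (0.19 log units; within the scatter)), and adding the fluoro to the plain phenyl also counts on this amine ring (a 2.5-fold lower number from compound 2 to compound 4 (0.39 log units; beyond the scatter)), so both halogen-bearing phenyl groups stand beyond the scatter from the plain phenyl of compound 2. With 2-fluorophenyl held constant, piperidin-3-yl and pyrrolidin-3-yl on the aromatic nitrogen are not separated either (no change at the digits printed from compound 1 to compound 4 (within the scatter)). No measurement at hand offers a reason for these results.

Still open, going by these compounds, is how a methoxy group or an amine on the phenyl ring would read. Also open, on these data alone, is whether 3-chlorophenyl on pyrrolidin-3-yl would match its piperidin-3-yl counterpart.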